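Estimating Clearance for an Unmeasured Difluorophenyl Compound

The source may report more compounds than this note shows. Statements on the series, on what has been measured and on what is new or still open speak of the compounds shown alone.

Medicinal chemists often ask how quickly the body removes a compound, and a single structural change can be followed on that question. For the measured compounds named here, in an ADME assay on the whole organism (Rattus norvegicus, strain Sprague-Dawley) for pharmacokinetics, using cassette dosing, at a dose of 0.5 mg/kg by the intravenous route (a higher number here means faster removal of the compound, a lower number slower removal), compound 1 `O=C(c1cc(-c2ccc(=O)[nH]c2)on1)N1CCC(Cc2ccccc2)CC1` gives 19.3 mL/min/kg, the only number available in this set. Compound 2 `O=C1Cc2cc(NC(=O)C(=O)N3CCN(c4ccc(Cl)cc4)CC3)ccc2N1` stands at "not determined" (no result reported). Compound 3 `O=C(Nc1ccc2[nH]c(=O)oc2c1)C(=O)N1CCN(c2ccccc2)CC1` stands at "not determined" (no result reported), so it has no place on the scale and cannot be ranked against compound 1.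

Compound 4 `O=C(Nc1ccc2[nH]c(=O)oc2c1)C(=O)N1CCN(c2ccc(F)c(F)c2)CC1` has not yet been measured. The structural change is 3,4-difluorophenyl in place of phenyl on an amine nitrogen in a ring, with 3,4-difluorophenyl in place of phenyl on an amine nitrogen in a ring. Going by the values given here, no measured pair here shows what such a swap does in this assay, so no step can be calculated. The expectation is therefore a step no larger than the usual scatter, with no favoured direction. The estimate leans loosely on compound 1 at 19.3 mL/min/kg, a structurally different compound, so the range is wide. In this assay, compound 4 is expected at about 20 mL/min/kg, with an estimated range of 7 mL/min/kg to 50 mL/min/kg.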

Compound 4, clearance: 4 mL/min/kg
Compound 4: middle estimate off by 5.0-fold (0.70 log units), on the high side; the measured number lies below the stated range.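

For the compounds shown here, with compound 3 carrying no number in this assay, no step to compound 4 can be read, even though compound 4 gives 4 mL/min/kg there. Going by these compounds, what replacing phenyl with 3,4-difluorophenyl does to clearance therefore stays open. Nothing shown here helps to explain the result.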